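The source may report more compounds than this note shows. Statements on the series, on what has been measured and on what is new or still open speak of the compounds shown alone.

Compound 1 `CCCCCCCCCCCCCCCC(=O)N[C@@H](CC(=O)O)CC(C)C` and compound 2 `CCCCCCCCCCCCCCCC(=O)N[C@@H](CCC(=O)O)CC(C)C` were both tested in an assay on isolated protein (Sus scrofa) with Group 10 secretory phospholipase A2 (Homo sapiens) as the target; on this read-out lower numbers stand for stronger inhibition and higher numbers for weaker inhibition. Compound 1 gives 7300 nM, and compound 2 gives 4500 nM; the step of a 1.6-fold lower number from compound 1 to compound 2 (0.21 log units; within the scatter) lies within the scatter, so the two numbers cannot be told apart. Compound 3 `CCCCCCCCCC(=O)N[C@@H](CC(=O)O)CC(C)C` has not yet been measured. It differs from compound 1 by hydrogen in place of hexyl on a saturated chain carbon, nine bonds along the chain from a carbonyl carbon, a shortening of the long chain. Going by the values given here, no measured step touches this change; the only measured step concerns the carboxy group, so there is no direct guide. For compound 3 in this assay a weaker result is expected, a 3.4-fold higher number from compound 1 to compound 3 (0.53 log units; beyond the scatter), giving an estimate of 25000 nM with a range from 7000 nM to 100000 nM.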

Compound 3, half-maximal inhibitory concentration: 15000 nM
Compound 3: the middle estimate sits 1.7-fold (0.22 log units) above what was measured, within the range that was stated.
By their numbers in this assay, from the lowest: compounds 2 and 1 (each within the scatter of the next); then compound 3.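

Removing part of the long chain has a readable effect in this assay on inhibition: hydrogen in place of hexyl, on a saturated chain carbon, nine bonds along the chain from a carbonyl carbon, gives a modest weakening (a 2.1-fold higher number from compound 1 to compound 3 (0.31 log units; beyond the scatter)). Unlike the earlier change at the carboxy group, this step lies beyond the scatter, so the outer part of the chain counts for something in this pair. No available evidence accounts for the loss. Still open, going by these compounds, is whether a longer chain would strengthen inhibition. Also open, on these data alone, is how an amine in place of the carboxylic acid would behave.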